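A few compounds are considered here, and "the series" means these few. Any claim that something is new, unique, unknown or untested is made for them only; others in the source may bear on it.

Compound 2 `CC(C)(NC(=O)c1cc(F)cc2cc(-c3ccc(Cl)cc3)oc12)c1nnn[nH]1` has no number in an assay on isolated protein for inhibition of endoplasmic reticulum aminopeptidase 2 (Homo sapiens); a higher number here means a weaker inhibitor, a lower number a stronger inhibitor: its result is recorded as "not determined" (no result reported). Compound 1 `O=C(NC1(C(=O)O)CCCCC1)c1cccc2cc(-c3ccc(Cl)cc3)oc12` gives > 30000 nM in this assay, which is a limit rather than a measured number (the limit of > 30000 nM in this assay, at which 1 of the 2 values shown sits). Compound 3 `O=C(NC1(C(=O)O)CCCC1)c1cc(F)cc2cc(-c3ccc(Cl)cc3)oc12` differs from compound 2 by 1-carboxycyclopentyl in place of 1-(1H-tetrazol-5-yl)-1-methylethyl on an amide-type nitrogen. With no number for compound 2, the size and direction of this step cannot be read from the data, so no shift beyond the scatter is claimed. Compound 3 sits close in structure to compound 1, and its potency in this assay is expected to be weak, estimated at 30000 nM, in a range from 8000 nM to 100000 nM.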

Compound 3, half-maximal inhibitory concentration: > 30000 nM
Compound 3: no number, only a limit (the forecaster's own chance of this, stated with the estimate: 65%); the middle value sits exactly at the limit.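

No step can be read between compound 2, which has no number, and compound 3. In this assay compound 3 gives > 30000 nM, which is a limit. The compounds shown leave open whether 1-(1H-tetrazol-5-yl)-1-methylethyl or 1-carboxycyclopentyl on the amide-type nitrogen gives the stronger inhibitor.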